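Chloro in Place of Carboxy: An Expected Outcome

The source may hold more compounds than are shown below. What is called first, only, known or untested is meant among the compounds shown, and "the series" means these compounds.

Compound 1, `Cc1cc(NC(=O)Nc2ccc(C(=O)O)cc2)c2ccccc2n1`, carries a carboxy group on its pendant aromatic ring. In an ADME assay on Raji cells (Homo sapiens) for cytotoxicity, with a stated time of 72 h (on this read-out higher numbers stand for an effect only at larger amounts of compound and lower numbers for an effect already at smaller amounts), compound 1 gives > 25000 nM, which is a limit of the assay and not a number. Compound 2, `Cc1cc(NC(=O)Nc2ccc(F)c(F)c2)c2ccccc2n1`, is no different: in this assay compound 2 gives > 25000 nM, again a limit. Compound 3, `Cc1cc(NC(=O)Nc2ccc3[nH]cnc3c2)c2ccccc2n1`, also gives > 25000 nM in this assay, once more a limit. All three measured compounds thus sit at the limit of > 25000 nM in this assay, at which 3 of the 3 values shown sit, so compound 1 has no rank among them; the numbers shown neither raise nor lower it against its companions.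

Compound 4, `Cc1cc(NC(=O)Nc2ccc(Cl)cc2)c2ccccc2n1`, remains to be measured. It differs from compound 1 in one place: chloro in place of carboxy on an aromatic carbon. Going by the values given here, no step between measured compounds exists here, so nothing measured tells how such a change moves the read-out. Since every measured compound rests at the limit of > 25000 nM in this assay, at which 3 of the 3 values shown sit, the step expected in this assay is none beyond the scatter, with another limit the likeliest result. Compound 4 is therefore expected to give 30000 nM, with a range from 8000 nM to 100000 nM, an expected step that the limit leaves unreadable from compound 1 to compound 4.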

Compound 4, half-maximal effective concentration: > 25000 nM
Compound 4 was reported as a limit; the forecaster's own chance of this, stated with the estimate: 75%; the middle value is on the limit's open side.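

In this assay compound 4 gives > 25000 nM, a limit and not a number. Compound 1 also stands at a limit, so no step between compound 1 and compound 4 can be read: the limit of > 25000 nM in this assay, at which 4 of the 4 values shown sit.

The compounds shown leave open whether chloro in place of carboxy moves this read-out at all.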